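A few compounds are considered here, and "the series" means these few. Any claim that something is new, unique, unknown or untested is made for them only; others in the source may bear on it.

Compound 3 `CNC(=O)/C=C/c1ccncc1-c1ccc2ccccc2c1` stands at the weak end of what has been measured: in a functional assay on HCT-116 cells (Homo sapiens) for inhibition, read by MTT assay, with a stated time of 72 h (on this read-out higher numbers stand for weaker inhibition of growth and lower numbers for stronger inhibition of growth), compound 3 gives 6550 nM, whereas compound 1 `CCOC(=O)/C=C/c1ccncc1-c1ccc2c(ccn2C)c1` gives 210 nM, and for compound 2 `COC1CN(C(=O)/C=C/c2ccncc2-c2ccc3[nH]ncc3c2)C1` the result is "not determined" (no result reported). Compound 4 `CCOC(=O)/C=C/c1ccncc1-c1ccc2ccccc2c1` shares the core of compound 3 and differs from it in one place: ethoxy in place of methylamino on a carbonyl carbon. Among the measured compounds shown here, no measured pair shows this change on its own, so the expectation rests on compound 1, whose ethoxy bearing structure gives 210 nM. The step from compound 3 to compound 4 is therefore expected to be sizeable, toward stronger growth inhibition, a 4.4-fold lower number from compound 3 to compound 4 (0.64 log units; beyond the scatter). Compound 4 is estimated at 1500 nM, within a range from 400 nM to 6000 nM.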

Compound 4, concentration for 50% growth inhibition: 910 nM
Estimate against measurement, compound 4: 1.6-fold (0.22 log units) above, within the range that was stated.
By their numbers in this assay, from the lowest: compound 1; then compound 4; then compound 3.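

Among the compounds shown here, on the shared core, this is the first direct reading of this change: ethoxy in place of methylamino on a carbonyl carbon gives a 7.2-fold lower number from compound 3 to compound 4 (0.86 log units; beyond the scatter). The group on this carbonyl carbon therefore matters for growth inhibition, even with the rest of the structure unchanged. Nothing shown here accounts for this step.

Going by these compounds, it remains open how a carboxylic acid or a chain longer than ethoxy would read on this carbonyl carbon. On these data alone, whether the same swap gives a similar step on the core of compound 1 is also open.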